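The source may report more compounds than this note shows. Statements on the series, on what has been measured and on what is new or still open speak of the compounds shown alone.

Compound 1 `COC(=O)C1=C(C)N=C(C)/C(=C(\O)OC)C1c1cccc(O)c1`: 1000 nM
Compound 2 `COC(=O)C1=C(C)N=C(C)/C(=C(\O)OC)C1c1cccc(C)c1`: 110 nM
Compound 3 `COC(=O)C1=C(C)N=C(C)/C(=C(\O)OC)C1c1ccc(Br)cc1`: 540 nM

In a functional assay (muscle tissue) with Cavia porcellus as the target (a lower number here means that less compound is needed, a higher number that more compound is needed for the effect), compound 3 gives 540 nM. That value lies within the scatter of compound 1, as a 1.9-fold lower number from compound 1 to compound 3 (0.27 log units; within the scatter) shows, and well apart from compound 2, as a 4.9-fold higher number from compound 2 to compound 3 (0.69 log units; beyond the scatter) shows.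

Compound 4 `COC(=O)C1=C(C)N=C(C)/C(=C(\O)OC)C1c1ccccc1C` has not yet been measured. Its change from compound 3 is 2-methylphenyl in place of 4-bromophenyl on a saturated ring carbon.

For the measured compounds named here, no measured compound carries 2-methylphenyl, so the evidence is indirect. The closest guide is the modest step of a 4.9-fold higher number from compound 2 to compound 3 (0.69 log units; beyond the scatter), where 4-bromophenyl replaced 3-methylphenyl. The step of a 9.1-fold lower number from compound 1 to compound 2 (0.96 log units; beyond the scatter) also favours the methyl-bearing compound 2. Returning to a methylphenyl group is therefore expected to give a modest step towards a lower number in this assay, although the shifted methyl position leaves this uncertain. The estimated step is a 7.7-fold lower number from compound 3 to compound 4 (0.89 log units; beyond the scatter). For compound 4, the estimated value is 70 nM, with an expected range of 18 nM to 270 nM.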

Compound 4, half-maximal effective concentration: 6.03 nM
Estimate against measurement, compound 4: 12-fold (1.06 log units) above; measured number below the stated range.
By their numbers in this assay, from the lowest: compound 4; then compound 2; then compounds 3 and 1 (each within the scatter of the next).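

In this assay, for the compounds shown here, moving the methyl group alone gives an 18-fold lower number from compound 2 to compound 4 (1.26 log units; beyond the scatter) as a large step, something the earlier compounds could not show, since they held only one methylphenyl group. The steps from the other two compounds are larger still, with a 90-fold lower number from compound 3 to compound 4 (1.95 log units; beyond the scatter) and a 170-fold lower number from compound 1 to compound 4 (2.22 log units; beyond the scatter) both beyond the scatter, so compound 4 has the lowest number of the four and the substitution pattern on this phenyl group matters greatly at this saturated ring carbon. Nothing shown gives a reason for the size of these steps.

The compounds shown leave open whether the step belongs to the methyl group itself or would also appear with 2-chlorophenyl or 2-methoxyphenyl in its place. As far as these compounds go, how unsubstituted phenyl or 4-methylphenyl would compare also remains open.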